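Swapping the Amide Aryl Group Once More

The source may report more compounds than this note shows. Statements on the series, on what has been measured and on what is new or still open speak of the compounds shown alone.

Three amides built on a shared core have been measured so far. Compound 1 `O=C(Nc1ccc(Cl)c(-c2nnc3c(Cl)cccn23)c1)c1cccnc1` carries pyridin-3-yl on the carbonyl carbon; in a functional assay on A549 cells (Homo sapiens) for antiproliferative activity, read by MTT assay, with a stated time of 72 h (on this read-out lower numbers stand for stronger inhibition and higher numbers for weaker inhibition), compound 1 gives only a limit, > 100000 nM. Compound 2 `O=C(Nc1ccc(Cl)c(-c2nnc3c(Cl)cccn23)c1)c1ccc(C(F)(F)F)cc1F` likewise gives only a limit in this assay, > 100000 nM. Compound 3 `CS(=O)(=O)c1ccc(C(=O)Nc2ccc(Cl)c(-c3nnc4c(Cl)cccn34)c2)cc1` carries 4-(methylsulfonyl)phenyl on the carbonyl carbon and also gives only a limit in this assay, > 100000 nM. Compound 3 therefore stands exactly where every measured value stands, namely at the limit of > 100000 nM in this assay, at which 3 of the 3 values shown sit. Among the measured compounds shown here, the one step between measured compounds, a step that the two limits leave unreadable from compound 1 to compound 3, cannot be read, since both of its ends are limits rather than numbers.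

Compound 4 `O=C(Nc1ccc(Cl)c(-c2nnc3c(Cl)cccn23)c1)c1ccccc1Cl` is the next variation on the same core: 2-chlorophenyl in place of 4-(methylsulfonyl)phenyl on a carbonyl carbon. For the measured compounds named here, the only step that bears on this change carries no readable size, and all three values shown are limits. No step beyond the scatter is therefore expected in this assay: compound 4 is expected to sit at 100000 nM, somewhere between 30000 nM and 300000 nM, which amounts to an expected step of a number no higher from compound 3 to compound 4 (the limit leaves the size open).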

Compound 4, half-maximal inhibitory concentration: > 100000 nM
Compound 4 gave a limit, no number (the forecaster's own chance of this, stated with the estimate: 80%); the middle value lies on the limit itself.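

In this assay compound 4 gives > 100000 nM, a limit and not a number, so neither its step from compound 1 nor its step from compound 3 can be read. Compounds 1, 2, 3 and 4 all stand together: the limit of > 100000 nM in this assay, at which 4 of the 4 values shown sit.

From the compounds shown here alone, what remains open is how much the amide aryl group matters, since none of these four compounds yields an actual number in this assay.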